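Cyano for benzoyl on a vinyl sulfone indole

This account rests on a few compounds, and the source may have more. Where it says the series, first, only, none or still open, it means among the compounds named here.

Compound 1: `O=C(/C(=C\c1c(-c2ccccc2)[nH]c2ccccc12)S(=O)(=O)c1ccccc1)c1ccccc1`, a functional assay on HCT-15 cells (Homo sapiens) for inhibition, read by sulforhodamine B assay, with a stated time of 48 h; a lower number here means a stronger inhibitor of growth, a higher number a weaker inhibitor of growth: "not determined" (no result reported)
Compound 2: `COc1ccc(-c2[nH]c3ccc(OC)cc3c2/C=C(\C#N)S(=O)(=O)c2ccccc2)cc1`, this assay: 632 nM

Compound 1 stands without a number in this assay; no result was reported for it, so its place among the measured values cannot be given. Within the data shown here, compound 2 is the only compound with a value, and in this assay compound 2 gives 632 nM. Among the measured compounds shown here, compound 2 carries a cyano group on the double-bonded chain carbon and two methoxy groups, so it is not a single-change neighbour of compound 1 and no step between the two is described.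

Compound 3, `N#C/C(=C\c1c(-c2ccccc2)[nH]c2ccccc12)S(=O)(=O)c1ccccc1`, is made from compound 1 by the change (cyano in place of benzoyl on a double-bonded chain carbon bound to a double-bonded chain carbon and a sulfonyl sulfur). Compound 1 has no number, so the size and direction of this step in this assay cannot be judged from the data. Only the value of compound 2, which shares the cyano group with compound 3, offers a point of reference.

Compound 3 is therefore expected to show a value near 1200 nM in this assay, with a likely range from 300 nM to 5000 nM.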

Compound 3, concentration for 50% growth inhibition: 1100 nM
Compound 3: the middle estimate sits 1.1-fold (0.04 log units) above what was measured; measured number inside the range.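

Among these compounds, compound 1 carries no number in this assay, and no step to compound 3 can be read from these results. The compounds shown leave open how replacing benzoyl with cyano changes growth inhibition in this setting. Nothing given here bears on the cause of the value of compound 3.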